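Dropping One Methoxy from the Aryl Ketone

A few compounds are considered here, and "the series" means these few. Any claim that something is new, unique, unknown or untested is made for them only; others in the source may bear on it.

Compound 3 `COc1ccc(C(=O)/C=C/c2cc(-c3cc(OC)c(OC)c(OC)c3)n[nH]2)cc1OC` gives 100% in a functional assay on SK-OV-3 cells (Homo sapiens) for cytotoxicity, read by sulforhodamine B assay, with a stated time of 48 h, tested at 0.01 uM (on this read-out lower numbers stand for a stronger effect and higher numbers for a weaker effect at the one concentration tested), the highest of the three numbers shown. Compound 2 `COc1cc(-c2cc(/C=C/C(=O)c3ccc(Cl)c(Cl)c3)[nH]n2)cc(OC)c1OC`, with 99%, lies within the scatter of that number, while compound 1 `COc1cc(-c2cc(/C=C/C(=O)c3ccc(N)cc3)[nH]n2)cc(OC)c1OC`, with 82%, lies beyond it. Compound 4 `COc1ccc(C(=O)/C=C/c2cc(-c3cc(OC)c(OC)c(OC)c3)n[nH]2)cc1` differs from compound 3 by hydrogen in place of methoxy on an aromatic carbon. The measured steps that bear on this all alter the same aromatic ring on the carbonyl carbon: a number 18 percentage points higher from compound 1 to compound 3 (beyond the scatter), and a number 1 percentage points higher from compound 2 to compound 3 (within the scatter). Neither removes a single methoxy, so they guide only loosely. Because a number 1 percentage points higher from compound 2 to compound 3 (within the scatter) stayed within the scatter despite exchanging the whole ring, compound 4 is expected to show no step beyond the scatter, a number 3 percentage points lower from compound 3 to compound 4 (within the scatter). Compound 4 is therefore estimated at 97%, between 84% and 105%.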

Compound 4, a percentage reported as activity, at one concentration (the size of the read-out at that concentration, not a potency): 100%
Compound 4: the middle estimate sits 3 percentage points below what was measured, and the stated range covers the measured number.
By their numbers in this assay, from the lowest: compound 1; then compounds 2, 3 and 4 (each within the scatter of the next).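

Removing one methoxy to turn 3,4-dimethoxyphenyl into 4-methoxyphenyl leaves the number in this assay in place (no change at the digits printed from compound 3 to compound 4 (within the scatter)), so this single position shows no effect at this concentration. The 4-methoxyphenyl ring also stays level with 3,4-dichlorophenyl (a number 1 percentage points higher from compound 2 to compound 4 (within the scatter)), while methoxy in place of amino gives a clear step (a number 18 percentage points higher from compound 1 to compound 4 (beyond the scatter)). Nothing at hand explains these numbers. Going by these compounds, whether a hydroxyl group or a fluorine atom at the emptied position would move the number remains open, as does the effect of this change at other concentrations.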